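This account rests on a few compounds, and the source may have more. Where it says the series, first, only, none or still open, it means among the compounds named here.

Measured in a functional assay on HCT-116 cells (Homo sapiens) for antiproliferative activity, read by sulforhodamine B assay, with a stated time of 72 h; a higher number here means a weaker inhibitor, a lower number a stronger inhibitor:
- compound 1 `CCCCS(=O)(=O)Nc1cc(-c2ccc3ncnc(NCCN(C)C)c3c2)cnc1OC`: 160 nM
- compound 2 `COc1ncc(-c2ccc3ncnc(NCCN(C)C)c3c2)cc1NS(=O)(=O)c1ccc(F)cc1`: 3200 nM

Among the measured compounds shown here, compound 1 holds the lower of the two numbers, and compound 2 is its only neighbour: a 20-fold higher number from compound 1 to compound 2 (1.30 log units; beyond the scatter). That large step is 4-fluorophenyl in place of butyl on a sulfonyl sulfur.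

Compound 3 `CCCCS(=O)(=O)Nc1cc(-c2ccc3ncnc(NCc4ccncc4)c3c2)cnc1OC` keeps the butyl group of compound 1 and changes the other end: pyridin-4-yl in place of (dimethylamino)methyl on a saturated chain carbon bound to a nitrogen on an aromatic ring. Cut one bond further out, this reads 2-(dimethylamino)ethyl to (pyridin-4-yl)methyl.

For the measured compounds named here, no measured step covers this place. Going by the values given here, the step to compound 2 shows only that one change can move the number far in this assay, so the expectation stays loose. A moderate move toward a higher number is expected, smaller than that step, and the expected step is a 2.5-fold higher number from compound 1 to compound 3 (0.40 log units; beyond the scatter). The estimate for compound 3 is 400 nM, with an expected range of 100 nM to 1600 nM.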

Compound 3, half-maximal inhibitory concentration: 5720 nM
The estimate for compound 3 lay 14-fold (1.16 log units) below the measured number; measured number outside the range, above it.
By their numbers in this assay, from the lowest: compound 1; then compounds 2 and 3 (each within the scatter of the next).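

With the butyl group held, the place on a saturated chain carbon bound to a nitrogen on an aromatic ring proves as open to large moves in this assay as the sulfonyl sulfur: pyridin-4-yl in place of (dimethylamino)methyl gives a large step (a 36-fold higher number from compound 1 to compound 3 (1.55 log units; beyond the scatter)). The (pyridin-4-yl)methyl group therefore does not stand in for 2-(dimethylamino)ethyl in this assay, and each of the two single changes made to compound 1 raises the number beyond the scatter. No supporting measurement bears on this step.

Still open, from the compounds shown here alone, is whether the step follows from losing the dimethylamino group or from bringing in the ring; a 3-(dimethylamino)propyl chain, a 2-(pyrrolidin-1-yl)ethyl chain or a (pyridin-4-yl)ethyl chain would help separate the two. Also open, going by these compounds, is how a propyl or pentyl group on the sulfonyl sulfur compares with butyl.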